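The compounds below may be only part of what the source reports. "The series", "measured", "known", "first", "only" and "open" are said of these compounds alone.

Two compounds have been measured in an assay on isolated protein for inhibition of Gonadotropin-releasing hormone receptor (Rattus norvegicus); a lower number here means a stronger inhibitor, a higher number a weaker inhibitor:

Compound 1, `CCCCn1c(SCc2cc([N+](=O)[O-])ccc2OC)nc2cc(NC(=O)NC(C)(C)C)ccc21`: 330 nM
Compound 2, `CCCn1c(SCc2cc([N+](=O)[O-])ccc2OC)nc2cc(NC(=O)NC(C)(C)C)cc(C(=O)OC)c21`: 280 nM

Compound 2 stands with the lower of the two numbers, but its gap to compound 1 is within the scatter of repeated measurements, so the two read as equivalent in this assay. Among the measured compounds shown here, compound 1 and compound 2 differ from each other in more than one place, so no single step can be drawn between them, and their values simply sit together.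

Compound 3, `CCCn1c(SCc2cc([N+](=O)[O-])ccc2OC)nc2cc(NC(=O)NC(C)(C)C)cc(C(=O)NC(C)(C)C)c21`, has not been measured. It differs from compound 2 by (tert-butyl)amino in place of methoxy on a carbonyl carbon, with the shared core and the remaining substituents unchanged. For the measured compounds named here, no measured pair isolates this change, so there is no basis for a direction. The step from compound 2 to compound 3 in this assay is expected to be small and probably not beyond the scatter. Compound 3 is therefore estimated at 250 nM, with a range from 80 nM to 800 nM, an expected step of a 1.1-fold lower number from compound 2 to compound 3 (0.05 log units; within the scatter).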

Compound 3, half-maximal inhibitory concentration: 490 nM
Beside the measured number, compound 3's estimate is 2.0-fold (0.29 log units) below it; measured number inside the range.
By their numbers in this assay, from the lowest: compounds 2, 1 and 3 (each within the scatter of the next).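

In this assay, among the compounds shown here, the exchange of methoxy for (tert-butyl)amino on a carbonyl carbon gives a 1.8-fold higher number from compound 2 to compound 3 (0.24 log units; within the scatter), the first reading of a single change at this place. It shows that methoxycarbonyl and (tert-butyl)carbamoyl read as equivalent here, even though the entering group has five heavy atoms against two and brings a hydrogen-bond donor. Nothing measured here offers an explanation for this result.

The compounds shown leave open whether this tolerance extends to other groups on the same carbonyl carbon, such as a hydroxyl group, which would give the carboxylic acid, or a plain amino group, which would give the primary amide. They also leave open how a smaller methylamino or a dimethylamino group, which has no amide hydrogen, would read.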